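Vero cell tolerance across two measured compounds and one untested

The source may hold more compounds than are shown below. What is called first, only, known or untested is meant among the compounds shown, and "the series" means these compounds.

Measured so far:
- compound 1, `Fc1ccc(-c2nc3c(NC4CCCC4)cc(Cl)cn3c2-c2ccnc(NC3CCCC3)n2)cc1`. In an ADME assay on Vero cells (Chlorocebus sabaeus) for cytotoxicity (a lower number here means that less compound is tolerated, a higher number that more compound is tolerated), compound 1 gives > 40000 nM, which is a limit of the assay and not a number.
- compound 2, `Fc1ccc(-c2nc3c(Br)cc(Br)cn3c2-c2ccnc(NC3CCCC3)n2)cc1`. In this assay compound 2 gives > 40000 nM, likewise a limit of the assay.

Compound 2 therefore stands at the limit in this assay, and it is not alone there: the limit of > 40000 nM in this assay, at which 2 of the 2 values shown sit. Within the data shown here, no step between measured compounds is available, so the two values show only that neither compound reaches a measurable half-maximal cytotoxic concentration.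

Compound 3, `Fc1ccc(-c2nc3c(NC4CCCC4)cc(Br)cn3c2-c2ccnc(NC3CCCC3)n2)cc1`, is not yet measured. It differs from compound 2 by cyclopentylamino in place of bromo on an aromatic carbon, two atoms from the ring nitrogen and meta to the bromo group that remains. Compound 1 carries cyclopentylamino at both positions and compound 2 bromo at both, and both sit at the limit, so for compound 3 the expected step is none beyond the scatter, with the value expected again at the limit: a step that the limit leaves unreadable from compound 2 to compound 3. Compound 3 is estimated at 60000 nM, within 30000 nM to 150000 nM.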

Compound 3, half-maximal cytotoxic concentration: > 40000 nM
Compound 3 gave a limit, no number; the forecaster's own chance of this, stated with the estimate: 85%; the middle value lies beyond the limit too.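

In this assay compound 3 gives > 40000 nM, a limit of the assay and not a number. The steps to compound 3 from compound 1 and from compound 2 cannot be read: the limit of > 40000 nM in this assay, at which 3 of the 3 values shown sit.

The compounds shown leave open where the half-maximal cytotoxic concentration of each lies, and whether exchanging bromo, chloro or cyclopentylamino changes it.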